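Phenyl for hydroxy on two differently joined cores

A few compounds are considered here, and "the series" means these few. Any claim that something is new, unique, unknown or untested is made for them only; others in the source may bear on it.

The series holds compound 1 `CN1CCC[C@H]1[C@@H]1COc2cc(O)ccc2O1`, compound 2 `CN1CCC[C@H]1[C@H]1COc2c(O)cccc2O1`, compound 3 `CN1CCC[C@H]1[C@@H]1COc2cc(-c3ccccc3)ccc2O1` and the still unmeasured compound 4 `CN1CCC[C@H]1[C@H]1COc2c(cccc2-c2ccccc2)O1`. Compound 1 and compound 2 have the same atoms joined differently; the difference between the two cores is not broken down here. In an assay on membranes from HEK293 cells for displacement of a labelled ligand from Neuronal acetylcholine receptor; alpha3/beta4 (Homo sapiens), with a stated time of 5 min (on this read-out higher numbers stand for weaker inhibition and lower numbers for stronger inhibition), compound 1 gives 1900 nM. Compound 2 reaches only a limit of this assay, > 100000 nM. Compound 3 gives 5400 nM in this assay. The change phenyl in place of hydroxy on an aromatic carbon made a 2.8-fold higher number from compound 1 to compound 3 (0.45 log units; beyond the scatter). Compound 4 carries the same kind of change relative to compound 2, (phenyl in place of hydroxy on an aromatic carbon), the place now being ortho to a fused ring and meta to a fused ring rather than meta and para. The expected step is a step that the limit leaves unreadable from compound 2 to compound 4, resting on the measured 2.8-fold higher number from compound 1 to compound 3 (0.45 log units; beyond the scatter) and on compound 2 sitting at the limit of > 100000 nM in this assay, at which 1 of the 3 values shown sits. Compound 4 is therefore estimated at 200000 nM, most likely reported again only as a limit.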

Compound 4, inhibition constant: 5300 nM
Beside the measured number, compound 4's estimate is 38-fold (1.58 log units) above it; the whole stated range lies above it.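

In this assay, phenyl in place of hydroxy gives an at least 18-fold lower number from compound 2 to compound 4 (1.27 log units; beyond the scatter), so the change does not carry over between the two cores, even in direction: the same change on two cores in this assay, a 2.8-fold higher number (0.45 log units; beyond the scatter) from compound 1 to compound 3 and an at least 18-fold lower number (1.27 log units; beyond the scatter) from compound 2 to compound 4, at least 53-fold (1.72 log units) apart, beyond the scatter of two such steps

The value of compound 2, > 100000 nM, is a limit of the assay and not a number. Among the compounds shown here, with only one pair on each core, the result shows that the step is not transferable here, but it does not separate the effect of the core from that of the place, and it does not give the full size of the step.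

As far as these compounds go, it remains open whether a methoxy group or an amine in place of phenyl would also diverge between the two cores. Also open, from the compounds shown here alone, is how phenyl and hydroxy compare at each place on a single core.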